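Swapping an ethoxy for a methylsulfanyl on a lactam core

This account rests on a few compounds, and the source may have more. Where it says the series, first, only, none or still open, it means among the compounds named here.

Of the compounds shown here, three sharing one core have been tested in a functional assay on HT-29 cells (Homo sapiens) for inhibition, read by sulforhodamine B assay, with a stated time of 72 h; on this read-out lower numbers stand for stronger inhibition and higher numbers for weaker inhibition. Compound 2 `CCOc1ccc(C2C(O)C(=O)N2c2cc(OC)c(OC)c(OC)c2)cc1` gives 15 nM. Compound 3 `CCOc1ccc(C2C(Oc3ccccc3)C(=O)N2c2cc(OC)c(OC)c(OC)c2)cc1` gives 388 nM. Compound 1 `COc1cc(N2C(=O)C(Oc3ccccc3)C2c2ccc(SC)cc2)cc(OC)c1OC` gives 336 nM. The step of a 26-fold higher number from compound 2 to compound 3 (1.41 log units; beyond the scatter) comes from this change: hydrogen in place of phenyl on an oxygen on a saturated carbon. The step of a 1.2-fold lower number from compound 3 to compound 1 (0.06 log units; within the scatter) comes from this change: methylsulfanyl in place of ethoxy on an aromatic carbon. Compound 4 `COc1cc(N2C(=O)C(O)C2c2ccc(SC)cc2)cc(OC)c1OC` has not yet been measured in this assay. It differs from compound 2 by this change: methylsulfanyl in place of ethoxy on an aromatic carbon. This is the same change that was made from compound 3 to compound 1, at the same place, but here it is made on the core of compound 2, which carries hydroxy where compound 3 carries phenoxy; how those two cores differ is given above. Because the measured step of a 1.2-fold lower number from compound 3 to compound 1 (0.06 log units; within the scatter) is within the scatter, the step from compound 2 to compound 4 is expected to be small as well, about a 1.2-fold lower number from compound 2 to compound 4 (0.06 log units; within the scatter). For compound 4 the estimated value in this assay is therefore 13 nM, likely between 5 nM and 35 nM.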

Compound 4, half-maximal inhibitory concentration: 15 nM
The estimate for compound 4 lay 1.2-fold (0.06 log units) below the measured number; measured number inside the range.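

In this assay, putting methylsulfanyl in place of ethoxy gives no change at the digits printed from compound 2 to compound 4 (within the scatter), and the same swap made on the compounds carrying phenoxy gives a matching result: the same change on two cores in this assay, a 1.2-fold lower number (0.06 log units; within the scatter) from compound 3 to compound 1 and no change at the digits printed (within the scatter) from compound 2 to compound 4, 1.2-fold (0.06 log units) apart, within the scatter of two such steps. Putting hydroxy in place of phenoxy gives a 22-fold lower number from compound 1 to compound 4 (1.35 log units; beyond the scatter), a large step that is repeated on the compounds carrying ethoxy: the same change on two cores in this assay, a 26-fold higher number (1.41 log units; beyond the scatter) from compound 2 to compound 3 and a 22-fold higher number (1.35 log units; beyond the scatter) from compound 4 to compound 1, 1.2-fold (0.06 log units) apart, within the scatter of two such steps. Across these four compounds, each change therefore carried over from one core to the other with its size intact, so the phenoxy-to-hydroxy step sets the large difference while the ethoxy-to-methylsulfanyl swap leaves the number unmoved, but this rests on just two cores in a single assay and does not explain why either step has the size it has.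

The compounds shown leave open whether other groups at the same place on the aromatic ring, such as an amine or a longer chain like butoxy, would be as quiet as methylsulfanyl. They also leave open how a methoxy or an amine would behave where hydroxy and phenoxy sit.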